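Working notes: replacing the 2,5-dihydroxyphenyl group

A few compounds are considered here, and "the series" means these few. Any claim that something is new, unique, unknown or untested is made for them only; others in the source may bear on it.

In a functional assay, read by Griess assay, with a stated time of 2.5 h (a lower number here means a stronger inhibitor, a higher number a weaker inhibitor), compound 2 `COc1cc(OC)c(OC)cc1/C=C/C(=O)c1cc(O)ccc1O` gives 2.44 ug/mL, and compound 1 `COc1cc(OC)c(OC)cc1/C=C/C(=O)c1ccc(Cl)cc1` gives 2.01 ug/mL. Going by the values given here, these are the only two measured values, and they lie within the scatter of each other, so compound 2 does not stand apart from compound 1.

The next compound, not yet measured, is compound 3 `COc1cc(OC)c(OC)cc1/C=C/C(=O)c1ccc(Br)cc1`. Its structural change from compound 2 is 4-bromophenyl in place of 2,5-dihydroxyphenyl on a carbonyl carbon. The 2,5-dihydroxyphenyl group therefore leaves the carbonyl carbon, and 4-bromophenyl takes its place.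

Among the compounds with values here, one measured step bears on this change: a 1.2-fold higher number from compound 1 to compound 2 (0.08 log units; within the scatter). That step alters the group at the same carbonyl carbon and stays within the scatter. Within the data shown here, a single step is thin evidence, and no measured compound yet carries 4-bromophenyl. The expectation in this assay is therefore no step beyond the scatter, with no firm direction. The estimated step is a 1.1-fold lower number from compound 2 to compound 3 (0.04 log units; within the scatter). For compound 3 the expected value is 2.2 ug/mL, with an estimated range from 1.2 ug/mL to 3.9 ug/mL.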

Compound 3, half-maximal inhibitory concentration: 2.22 ug/mL
For compound 3 the middle estimate is 1.0-fold (0.00 log units) below the measured one; the measured number falls inside the stated range.
By their numbers in this assay, from the lowest: compounds 1, 3 and 2 (each within the scatter of the next).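

Swapping 2,5-dihydroxyphenyl on the carbonyl carbon for 4-bromophenyl in this assay gives a 1.1-fold lower number from compound 2 to compound 3 (0.04 log units; within the scatter) even though the entering group has 0 hydrogen-bond donors and 0 hydrogen-bond acceptors, whereas the leaving group has 2 of each. Going by these compounds alone, the halogen exchange, seen here for the first time, gives a 1.1-fold higher number from compound 1 to compound 3 (0.04 log units; within the scatter) and so does not separate 4-bromophenyl from 4-chlorophenyl. No supporting evidence is available to explain why these three groups read alike.

The compounds shown leave open whether any group at this carbonyl carbon would move the number beyond the scatter, since all three carry a substituted phenyl and none has a phenyl bearing an amine or a carboxylic acid, or a longer chain in place of the phenyl. As far as these compounds go, the shared core is also the same throughout, so the effect of a change there on the reading remains open.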